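The source may report more compounds than this note shows. Statements on the series, on what has been measured and on what is new or still open speak of the compounds shown alone.

Compound 1 `COc1ccc(CN(C(=O)CSC(=S)N2CCCc3cc(C)ccc32)c2cc(OC)c(OC)c(OC)c2)cc1` and compound 2 `COc1ccc(CN(C(=O)CSC(=S)N2CCCc3cc(OC)ccc32)c2cc(OC)c(OC)c(OC)c2)cc1` share one core, while compound 3 `COc1ccc(CN(C(=O)CSC(=S)N2CCN(C(=O)OC(C)(C)C)CC2)c2ccc(C)cc2)cc1` and compound 4 `COc1ccc(CN(C(=O)CSC(=S)N2CCN(C(=O)OC(C)(C)C)CC2)c2ccc(OC)cc2)cc1` share another; the difference between the two cores is not broken down here. In a functional assay on MGC-803 cells (Homo sapiens) for inhibition, read by CCK-8 assay, with a stated time of 48 h (a higher number here means a weaker inhibitor, a lower number a stronger inhibitor), compound 1 gives 6490 nM and compound 2 gives 8210 nM. The change between them, (methoxy in place of methyl on an aromatic carbon), made a 1.3-fold higher number from compound 1 to compound 2 (0.10 log units; within the scatter). In this assay compound 3 gives only a limit of the assay, > 20000 nM, not a number. Compound 4 carries the same kind of change, (methoxy in place of methyl on an aromatic carbon), on a ring that is not part of a fused or bridged system, para to a large group rather than meta to a fused ring and para to a fused ring. Because the earlier matching change gave a 1.3-fold higher number from compound 1 to compound 2 (0.10 log units; within the scatter), compound 4 is expected to land near 30000 nM, between 12000 nM and 80000 nM. The expected step is a step that the limit leaves unreadable from compound 3 to compound 4, and a limit rather than a number again seems likely.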

Compound 4, half-maximal inhibitory concentration: > 20000 nM
Compound 4 gave a limit, no number (the forecaster's own chance of this, stated with the estimate: 80%); the middle value lies beyond the limit too.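

No step can be read between compound 3 and compound 4, because both stop at the same limit rather than giving a number: the limit of > 20000 nM in this assay, at which 2 of the 4 values shown sit.

The compounds shown leave open whether going from 4-methylphenyl to 4-methoxyphenyl on this core changes inhibition at all.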